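Replacing a Pyrazole with an Amino Acid Side Chain

The source may hold more compounds than are shown below. What is called first, only, known or untested is meant among the compounds shown, and "the series" means these compounds.

Compound 1 `Cc1cc(N/C=C2\C(=O)NN=C2c2ccccc2)n[nH]1`: 96100 nM
Compound 2 `O=C1NN=C(c2ccccc2)/C1=C/Nc1cc(-c2ccccc2)[nH]n1`: 42700 nM

In a functional assay on MDA-MB-361 cells (Homo sapiens) for antiproliferative activity, read by MTT assay, with a stated time of 72 h (a higher number here means a weaker inhibitor, a lower number a stronger inhibitor), compound 1 gives 96100 nM, the highest of the two numbers measured, so it is the weaker of the pair. Compound 2 gives 42700 nM; the step of a 2.3-fold lower number from compound 1 to compound 2 (0.35 log units; beyond the scatter) is modest. Compound 3 `CSC[C@H](N/C=C1\C(=O)NN=C1c1ccccc1)C(=O)O` differs from compound 1 in one place: 1-carboxy-2-(methylsulfanyl)ethyl in place of 5-methyl-1H-pyrazol-3-yl on an amine nitrogen. The five-membered aromatic ring of the 5-methyl-1H-pyrazol-3-yl leaves, and a 1-carboxy-2-(methylsulfanyl)ethyl with no ring enters on the amine nitrogen. Among the compounds with values here, no measured step bears directly on this change: the only known step, a 2.3-fold lower number from compound 1 to compound 2 (0.35 log units; beyond the scatter), alters the pyrazole that is itself removed here, so it offers little guidance. Both measured numbers are high, and no step beyond the scatter is expected in either direction, though the uncertainty is wide. Compound 3 is estimated at 120000 nM (range 30000 nM to 400000 nM), an expected step of a 1.2-fold higher number from compound 1 to compound 3 (0.10 log units; within the scatter).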

Compound 3, half-maximal inhibitory concentration: 97400 nM
Compound 3: middle estimate off by 1.2-fold (0.09 log units), on the high side, within the range that was stated.
By their numbers in this assay, from the lowest: compound 2; then compounds 1 and 3 (each within the scatter of the next).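

In this assay, the step of a 1.0-fold higher number from compound 1 to compound 3 (0.01 log units; within the scatter) shows that the group on this amine nitrogen can be exchanged for a very different one without moving the number beyond the scatter. Until now, only a substituent on the pyrazole had been varied; here the whole 5-methyl-1H-pyrazol-3-yl gives way to the ring-free 1-carboxy-2-(methylsulfanyl)ethyl, so an aromatic ring at this place is not needed to hold this level of activity, which remains weak. No measurement here explains why these two groups read alike.

Going by these compounds, it remains open which part of the new group matters, the carboxylic acid or the methylsulfanyl chain. On these data alone, it is also open whether a methyl ester or a longer chain on this nitrogen would give a lower number.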